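The compounds below may be only part of what the source reports. "The series", "measured", "known", "first", "only" and "open" are said of these compounds alone.

Measured so far in a functional assay on HEK293 cells for positive allosteric modulation of metabotropic glutamate receptor 5 (Rattus norvegicus), read by fluorescence and calcium flux; on this read-out higher numbers stand for larger maximal responses and lower numbers for smaller maximal responses:
- compound 1, `C[C@@H](NC(=O)c1ccc(C#Cc2ccccc2F)cn1)C(C)(C)O`: 60%
- compound 2, `C[C@@H](NC(=O)c1ccc(C#CC2CC2)cn1)C(C)(C)O`: 63.4%
- compound 3, `CCCNC(=O)c1ccc(C#Cc2cccc(F)c2)cn1`: 65.9%

Compound 3 holds the largest of the three numbers, but its gaps to compound 2 and to compound 1 are both within the scatter, so the three stand level for practical purposes. Among the compounds with values here, the single step between two measured compounds that differ in one place, a number 3.4 percentage points higher from compound 1 to compound 2 (within the scatter), concerns the group on the triple-bonded carbon and leaves the amide side untouched.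

Compound 4, `CC(C)(O)CNC(=O)c1ccc(C#Cc2cccc(F)c2)cn1`, differs from compound 3 at the amide side only: 1-hydroxy-1-methylethyl in place of ethyl on a saturated chain carbon bound to an amide-type nitrogen. Within the data shown here, no measured step covers this change directly. What can be drawn on is that compound 1 and compound 2 both carry a 1-hydroxy-1-methylethyl group on the chain carbon bound to the amide-type nitrogen: in this assay compound 1 gives 60% and compound 2 gives 63.4%, numbers that do not differ from compound 3 beyond the scatter. On that basis compound 4 is expected to stay near compound 3, with a step of a number 3.9 percentage points lower from compound 3 to compound 4 (within the scatter) that is not expected to exceed the scatter. The estimate for compound 4 is 62%, within 50% to 75%.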

Compound 4, largest response reached (reported as efficacy), in percent of the reference or control that the assay uses: 61.5%
For compound 4 the middle estimate is 0.5 percentage points above the measured one, within the range that was stated.
By their numbers in this assay, from the lowest: compounds 1, 4, 2 and 3 (each within the scatter of the next).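

Within the data shown here, this is the first direct reading at the amide side of the series: in this assay, 1-hydroxy-1-methylethyl in place of ethyl on a saturated chain carbon bound to an amide-type nitrogen gives a number 4.4 percentage points lower from compound 3 to compound 4 (within the scatter) and so no shift that can be told from the scatter. Compounds 1 and 2 carried the hydroxylated group only with other groups on the triple-bonded carbon and had no partner differing at the amide side alone, whereas this pair shows that, on the core of compound 3, the maximal response holds when the group with more heavy atoms and an added hydrogen-bond donor and acceptor enters. No available evidence bears on why the number holds.

Open, on these data alone, is whether the maximal response also holds with an amine or a carboxylic acid at this place, or with a longer chain. Also open, as far as these compounds go, is whether the same change reads alike with cyclopropyl or 2-fluorophenyl on the triple-bonded carbon.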